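The source may hold more compounds than are shown below. What is called first, only, known or untested is meant among the compounds shown, and "the series" means these compounds.

Measured so far:
compound 1, `CCCCC(CC)C/N=C(\NC#N)Nc1cccnc1`: > 50 mg/kg
compound 2, `CC(C)(C)C(C)(C)/N=C(\NC#N)Nc1cccnc1`: 50 mg/kg
compound 3, `CC(C)(C)C/N=C(\NC#N)Nc1ccncc1`: 5 mg/kg

In a functional assay on the whole organism (blood, strain Wistar-Okamoto) with Rattus norvegicus as the target, with a stated time of 5 days (a higher number here means that more compound is needed for the effect, a lower number that less compound is needed), compound 1 gives only a limit, > 50 mg/kg, and no number is known for it (the limit of > 50 mg/kg in this assay, at which 1 of the 3 values shown sits). Compound 2 gives 50 mg/kg and compound 3 gives 5 mg/kg, so compound 3 holds the lowest of the two numbers shown, and its gap to compound 2 lies beyond the scatter. Compound 4, `CCC(CC)/N=C(\NC#N)Nc1ccncc1`, is not yet measured. It differs from compound 3 in one place: pentan-3-yl in place of neopentyl on a double-bonded nitrogen. Going by the values given here, no step between measured compounds covers this swap, so no direction can be read off, and in this assay a step within the scatter is expected. Compound 4 is expected to give 8 mg/kg, within 3 mg/kg to 25 mg/kg. The expected step is a 1.6-fold higher number from compound 3 to compound 4 (0.20 log units; within the scatter).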

Compound 4, minimum effective dose: 2.5 mg/kg
Estimate against measurement, compound 4: 3.2-fold (0.51 log units) above; measured number below the stated range.
By their numbers in this assay, from the lowest: compounds 4 and 3 (each within the scatter of the next); then compound 2.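

Pentan-3-yl in place of neopentyl on a double-bonded nitrogen gives a 2.0-fold lower number from compound 3 to compound 4 (0.30 log units; within the scatter) in this assay, so at this position the two groups, with the same atoms joined differently, cannot be told apart. Going by these compounds alone, this rests on a single pair, the only step that can be read so far. Nothing measured here gives a reason for this result.

Going by these compounds, whether a longer chain, a cyclohexyl group or an amine in this place would stay within the scatter of these two remains open. Compound 1 and compound 2 differ from compound 3 and compound 4 in more than one place, so they do not settle this.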